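Replacing the cyclobutyl group on the ether oxygen

A few compounds are considered here, and "the series" means these few. Any claim that something is new, unique, unknown or untested is made for them only; others in the source may bear on it.

In a functional assay on MCF7 cells (Homo sapiens) for antiproliferative activity, read by MTT assay, with a stated time of 48 h (a lower number here means a stronger inhibitor, a higher number a weaker inhibitor), the measured compounds give:
- compound 1 `COc1cc(-c2nnc3c(OC)cc(-c4ccc5[nH]ccc5c4)cn23)cc(OC)c1OC`: 80 nM
- compound 2 `COc1cc(-c2nnc3c(OC(C)C)cc(-c4ccc5[nH]ccc5c4)cn23)cc(OC)c1OC`: 1020 nM
- compound 3 `COc1cc(-c2nnc3c(OC4CCC4)cc(-c4ccc5[nH]ccc5c4)cn23)cc(OC)c1OC`: 267 nM

Compound 3 stands second highest of the three numbers, above compound 1 and below compound 2. Compound 4 `COc1cc(-c2nnc3c(OC4CN(C(C)(C)C)C4)cc(-c4ccc5[nH]ccc5c4)cn23)cc(OC)c1OC` carries 1-(tert-butyl)azetidin-3-yl in place of cyclobutyl on an oxygen on an aromatic ring. Three measured steps change this same group. Replacing methyl gave a large step (a 13-fold higher number from compound 1 to compound 2 (1.11 log units; beyond the scatter)) and a modest one (a 3.3-fold higher number from compound 1 to compound 3 (0.52 log units; beyond the scatter)), and cyclobutyl in place of isopropyl gave another modest step (a 3.8-fold lower number from compound 2 to compound 3 (0.58 log units; beyond the scatter)). Going by the values given here, no measured compound has nitrogen in this group, so the expectation is uncertain. A modest rise is expected in this assay. The estimated change is a 2.2-fold higher number from compound 3 to compound 4 (0.35 log units; beyond the scatter). The expected value for compound 4 is 600 nM (estimated range 150 nM to 2500 nM).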

Compound 4, half-maximal inhibitory concentration: > 10000 nM
Compound 4 gave a limit, no number (the forecaster's own chance of this, stated with the estimate: 5%); middle value at least 16-fold (1.22 log units) from the limit.
By their numbers in this assay, from the lowest: compound 1; then compound 3; then compound 2. At a limit, above all of these: compound 4.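

In this assay compound 4 gives no number, only a limit: the limit of > 10000 nM in this assay, at which 1 of the 4 values shown sits.

Methyl, isopropyl and cyclobutyl on this oxygen all gave measured values, so the position had shown graded changes, whereas 1-(tert-butyl)azetidin-3-yl takes activity out of the assay's measured range. This change gives an at least 37-fold higher number from compound 3 to compound 4 (1.57 log units; beyond the scatter), an at least 9.8-fold higher number from compound 2 to compound 4 (0.99 log units; beyond the scatter) and an at least 120-fold higher number from compound 1 to compound 4 (2.09 log units; beyond the scatter).

Compound 4 brings in the ring nitrogen and the tert-butyl group together, so the compounds shown leave open which of the two carries this loss. Going by these compounds, how a plain azetidin-3-yl or a cyclobutyl bearing tert-butyl would stand remains open.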